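Trimming tert-butyl to isopropyl: an expectation

The source may report more compounds than this note shows. Statements on the series, on what has been measured and on what is new or still open speak of the compounds shown alone.

Compound 1 `C[C@H](NC(=O)c1c(Cc2cc(F)c(Cl)cc2Cl)sc2c1CCOC2)c1ccc(C(=O)O)cc1`: 2.5 nM
Compound 2 `C[C@H](NC(=O)c1c(Cc2ccc(C(C)(C)C)cc2)sc2c1CCOC2)c1ccc(C(=O)O)cc1`: 9.5 nM

Among the compounds with values here, in a functional assay on CHO/Galpha16 cells for antagonist activity at prostaglandin E2 receptor EP4 subtype (Homo sapiens), read by calcium flux, with a stated time of 15 min (on this read-out lower numbers stand for stronger inhibition and higher numbers for weaker inhibition), compound 2 gives the higher of the two numbers; the single measured step, a 3.8-fold higher number from compound 1 to compound 2 (0.58 log units; beyond the scatter), exchanges one aryl group for another. Compound 3 `CC(C)c1ccc(Cc2sc3c(c2C(=O)N[C@@H](C)c2ccc(C(=O)O)cc2)CCOC3)cc1` differs from compound 2 by hydrogen in place of methyl on a saturated chain carbon bound to an aromatic carbon and two saturated chain carbons. Within the data shown here, no measured step covers a change of this kind, and the modest aryl exchange does not speak to it. A step within the usual scatter is therefore expected, a 1.1-fold higher number from compound 2 to compound 3 (0.02 log units; within the scatter). Compound 3 is estimated at 10 nM, with a range from 4 nM to 25 nM.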

Compound 3, half-maximal inhibitory concentration: 2.7 nM
Compound 3: middle estimate off by 3.7-fold (0.57 log units), on the high side; measured number outside the range, below it.
By their numbers in this assay, from the lowest: compounds 1 and 3 (each within the scatter of the next); then compound 2.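

Cutting a single methyl, tert-butyl to isopropyl, is not a silent trim at this position: in this assay it gives a 3.5-fold lower number from compound 2 to compound 3 (0.55 log units; beyond the scatter) and so recovers a real step. Set against the 2,4-dichloro-5-fluorophenyl group, 4-isopropylphenyl gives a 1.1-fold higher number from compound 1 to compound 3 (0.03 log units; within the scatter), so these two quite different aryl groups cannot be told apart here. Nothing measured here explains why one methyl matters this much. Open remains what an ethyl, a cyclopropyl or a methoxy group would give in place of isopropyl.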